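Dimethylamino in place of hydroxy on compound 3

The source may report more compounds than this note shows. Statements on the series, on what has been measured and on what is new or still open speak of the compounds shown alone.

In a functional assay on MCF7 cells (Homo sapiens) for inhibition, read by sulforhodamine B assay, with a stated time of 72 h (on this read-out higher numbers stand for weaker inhibition of growth and lower numbers for stronger inhibition of growth), compound 1 (`CCOC(=O)/C=C/c1ccncc1-c1ccc2c(cnn2C)c1`) gives 7320 nM and compound 2 (`CNC(=O)/C=C/c1ccncc1-c1ccc2cc[nH]c2c1`) gives 9230 nM with the two values inside the usual scatter of each other. These two compounds are not linked by a change at a single place.

Compound 3 (`O=C(O)/C=C/c1ccncc1-c1ccc2ccccc2c1`) returns only a limit in this assay with > 10000 nM as its reading and no number, so its place in the series is not fixed.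

Compound 4 (`CN(C)C(=O)/C=C/c1ccncc1-c1ccc2ccccc2c1`) carries dimethylamino in place of hydroxy on a carbonyl carbon, which turns carboxy into dimethylcarbamoyl (dimethylamino in place of hydroxy on a carbonyl carbon). Within the data shown here, no measured pair isolates this change, so its size cannot be read directly.

The expectation leans on compound 2, an amide at 9230 nM in this assay and on compound 1, an ester at 7320 nM in the same test, since both give numbers and neither carries carboxy. The expected step of an at least 1.2-fold lower number from compound 3 to compound 4 (0.09 log units; that floor lies within the scatter) is small and points toward stronger inhibition of growth, although a reading that again gives only a limit remains possible. Compound 4 is estimated at 8000 nM with an expected range from 3000 nM to 20000 nM in this assay as the working figure.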

Compound 4, concentration for 50% growth inhibition: 8190 nM
Beside the measured number, compound 4's estimate is 1.0-fold (0.01 log units) below it, and the stated range covers the measured number.
By their numbers in this assay, from the lowest: compounds 1, 4 and 2 (each within the scatter of the next). At a limit, above all of these: compound 3.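

In this assay, dimethylamino in place of hydroxy on a carbonyl carbon gives an at least 1.2-fold lower number from compound 3 to compound 4 (0.08 log units; that floor lies within the scatter). Among these compounds, on the core shared by compound 3 and compound 4, the dimethylcarbamoyl group therefore returns a measured number at the position where carboxy returns only a limit, and this is the first single-place change that can be read at all, though only in its direction and only as a floor inside the scatter. The reading of compound 3 is a limit and not a number, so the full size of the step stays unfixed because of that limit: the limit of > 10000 nM in this assay, at which 1 of the 4 values shown sits.

On these data alone, whether a pyrrolidine amide, an unsubstituted carboxamide or an ethyl ester on this same core would read differently from compound 4 remains open, as does the effect of a longer chain in place of the ethenyl link. Compound 1 and compound 2 differ from compound 4 in more than one place, so they do not show how much of the reading of compound 4 belongs to the dimethylcarbamoyl group and how much to the core.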